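Dropping the methylene and chlorine from a benzimidazole arm

The compounds below may be only part of what the source reports. "The series", "measured", "known", "first", "only" and "open" are said of these compounds alone.

Compound 3 `CN(CCNCc1cn(Cc2nc3cc(Cl)ccc3[nH]2)nn1)CCNc1ccnc2cc(Cl)ccc12` gives 59000 nM in a functional assay on NCI-H460 cells (Homo sapiens) for antiproliferative activity, read by sulforhodamine B assay, with a stated time of 72 h (a lower number here means a stronger inhibitor, a higher number a weaker inhibitor), the highest of the two plain numbers recorded, with compound 1 `CN(CCNCc1cn(-c2ccccc2)nn1)CCNc1ccnc2cc(Cl)ccc12` at 25000 nM as its nearest neighbour. Compound 2 `CN(CCNCc1cn(CCCO)nn1)CCNc1ccnc2cc(Cl)ccc12` reached only the limit of > 200000 nM in this assay, so it is a limit and not a number. Compound 4 `CN(CCNCc1cn(-c2nc3ccccc3[nH]2)nn1)CCNc1ccnc2cc(Cl)ccc12` differs from compound 3 by 1H-benzimidazol-2-yl in place of (5-chloro-1H-benzimidazol-2-yl)methyl on an aromatic nitrogen. The most relevant measured step is a 2.4-fold higher number from compound 1 to compound 3 (0.37 log units; beyond the scatter), where a directly attached phenyl gave way to a benzimidazolylmethyl; the step of an at least 3.3-fold lower number from compound 2 to compound 3 (0.53 log units; beyond the scatter) also touches this position. Compound 4 once more carries an aromatic ring directly on that nitrogen, so a modest gain is expected, a 1.7-fold lower number from compound 3 to compound 4 (0.23 log units; within the scatter). Compound 4 is therefore estimated at 35000 nM, likely between 12000 nM and 110000 nM.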

Compound 4, half-maximal inhibitory concentration: 33000 nM
For compound 4 the middle estimate is 1.1-fold (0.03 log units) above the measured one, within the range that was stated.
By their numbers in this assay, from the lowest: compounds 1, 4 and 3 (each within the scatter of the next, the first and the last beyond it). At a limit, above all of these: compound 2.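

A 1H-benzimidazol-2-yl set directly on the aromatic nitrogen reads much like the phenyl, a 1.3-fold higher number from compound 1 to compound 4 (0.12 log units; within the scatter), and removing the methylene and the chlorine together gives a 1.8-fold lower number from compound 3 to compound 4 (0.25 log units; within the scatter), so neither change leaves the scatter. All three aromatic arms therefore stay in one narrow band, and the 3-hydroxypropyl arm stands apart, an at least 6.0-fold lower number from compound 2 to compound 4 (0.78 log units; beyond the scatter). Compound 2 is a limit and not a number: the limit of > 200000 nM in this assay, at which 1 of the 4 values shown sits.

From the compounds shown here alone, the methylene and the chlorine change together, so their separate contributions stay open. Going by these compounds, how a pyridine or a phenyl bearing an amine would read at this position also remains open.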